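The source may report more compounds than this note shows. Statements on the series, on what has been measured and on what is new or still open speak of the compounds shown alone.

Measured so far:
- compound 1, `COc1ccccc1C(=O)Nc1cccc(-c2oc3cc(-c4ccc(F)cc4)ccc3c(=O)c2O)c1`, which in a functional assay on A549 cells (Homo sapiens) for antiproliferative activity, read by CCK-8 assay, with a stated time of 72 h (on this read-out higher numbers stand for weaker inhibition and lower numbers for stronger inhibition), gives 11700 nM
- compound 2, `Cc1cc(C)cc(C(=O)Nc2cccc(-c3oc4cc(-c5ccc(F)cc5)ccc4c(=O)c3O)c2)c1`, which in this assay gives 3740 nM

Among the measured compounds shown here, compound 2 gives the lowest of the two numbers, and the only step so far, a 3.1-fold lower number from compound 1 to compound 2 (0.50 log units; beyond the scatter), separates it from compound 1. The unmeasured compound 3 is `O=C(Nc1cccc(-c2oc3cc(-c4ccc(F)cc4)ccc3c(=O)c2O)c1)c1ccc([N+](=O)[O-])cc1`. It differs from compound 2 in one place: 4-nitrophenyl in place of 3,5-dimethylphenyl on a carbonyl carbon. For the measured compounds named here, no measured step involves a 4-nitrophenyl group, so the only guide is that a change of the ring on the carbonyl carbon moved the number by a modest amount in the one case seen, a 3.1-fold lower number from compound 1 to compound 2 (0.50 log units; beyond the scatter). For compound 3 a step of a 1.5-fold higher number from compound 2 to compound 3 (0.17 log units; within the scatter) is therefore expected, that is, a change not clearly beyond the scatter, with some lean toward a higher number. The estimate for compound 3 in this assay is 5500 nM, within a range from 1500 nM to 20000 nM.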

Compound 3, half-maximal inhibitory concentration: 2440 nM
For compound 3 the middle estimate is 2.3-fold (0.35 log units) above the measured one, within the range that was stated.
By their numbers in this assay, from the lowest: compounds 3 and 2 (each within the scatter of the next); then compound 1.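

In this assay, a second, quite different ring on this carbonyl carbon gives a result that cannot be told apart from the first: a 1.5-fold lower number from compound 2 to compound 3 (0.19 log units; within the scatter) leaves 4-nitrophenyl and 3,5-dimethylphenyl level, although one brings nitrogen and oxygen atoms and the other only carbon. By contrast, a 4.8-fold lower number from compound 1 to compound 3 (0.68 log units; beyond the scatter) is a change beyond the scatter, so 2-methoxyphenyl now stands apart from two other rings rather than from one. No measurement shown here explains why these rings compare as they do.

Still open, going by these compounds, is whether a ring is needed on this carbonyl carbon at all, or whether a plain methyl group or a longer alkyl chain would serve. Also open, on these data alone, is how a phenyl ring carrying an amine or a carboxylic acid would compare.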